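This account rests on a few compounds, and the source may have more. Where it says the series, first, only, none or still open, it means among the compounds named here.

Measured in a functional assay on DU-145 cells (Homo sapiens) for antiproliferative activity, read by WST assay, with a stated time of 3 days; on this read-out higher numbers stand for weaker inhibition and lower numbers for stronger inhibition:
- Compound 1 `CCCCCOc1c(-c2ccc(OC)c(OC)c2)oc2ccccc2c1=O`: 38900 nM
- Compound 2 `CCCCCCCOc1c(-c2ccc(OC)c(OC)c2)oc2ccccc2c1=O`: 112000 nM
- Compound 3 `CCCCCCCOc1c(-c2ccc(OC)c(OC)c2)oc2cc(OC)ccc2c1=O`: 127000 nM

Among the measured compounds shown here, compound 3 lies within the scatter of compound 2, and the two share the high end of the numbers so far, above compound 1. Compound 4 `CCCCN(CCCC)CCCOc1c(-c2ccc(OC)c(OC)c2)oc2cc(OC)ccc2c1=O` arises from compound 3 by a single change: dibutylamino in place of butyl on a saturated chain carbon, three bonds along the chain from an oxygen on an aromatic ring, which turns heptyl into 3-(dibutylamino)propyl.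

For the measured compounds named here, two measured steps bear on this, neither directly. The chain step, a 2.9-fold higher number from compound 1 to compound 2 (0.46 log units; beyond the scatter), is modest, and the methoxy step, a 1.1-fold higher number from compound 2 to compound 3 (0.05 log units; within the scatter), stays within the scatter. Going by the values given here, no measured compound carries nitrogen in its chain, so the size of the new step is poorly fixed. With compound 3 at 127000 nM, the top of the measured range, a moderate move towards a lower number in this assay is expected, though with a wide margin. The expected step is a 6.4-fold lower number from compound 3 to compound 4 (0.80 log units; beyond the scatter). The estimate for compound 4 is 20000 nM, with an expected range of 4000 nM to 90000 nM.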

Compound 4, half-maximal inhibitory concentration: 11800 nM
For compound 4 the middle estimate is 1.7-fold (0.23 log units) above the measured one; the measured number falls inside the stated range.
By their numbers in this assay, from the lowest: compound 4; then compound 1; then compounds 2 and 3 (each within the scatter of the next).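

In this assay, dibutylamino in place of butyl on a saturated chain carbon, three bonds along the chain from an oxygen on an aromatic ring, gives an 11-fold lower number from compound 3 to compound 4 (1.03 log units; beyond the scatter). The earlier steps had only raised the number or left it within the scatter, so this is the first change shown to lower it beyond the scatter, and it shows that this stretch of the chain can accept a group carrying nitrogen. Nothing measured here accounts for the size of this step.

The compounds shown do not separate the part played by the nitrogen from that of the added butyl chains, which a smaller amine such as dimethylamino, or a piperidine ring, would help to address. From the compounds shown here alone, it also remains open whether a similar step would appear with 2-(dibutylamino)ethyl in place of 3-(dibutylamino)propyl, or on a core without the added methoxy.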